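The source may hold more compounds than are shown below. What is called first, only, known or untested is meant among the compounds shown, and "the series" means these compounds.

Working notes on the ester series built on a shared core. Compound 1 `COc1ccc(C(=O)OCC2Oc3ccc([C@H]4Oc5cc(O)cc(O)c5C(=O)[C@@H]4O)cc3OC2c2ccc(O)c(OC)c2)cc1` gives 73300 nM in a functional assay, read by spectrophotometry, with a stated time of 30 min; on this read-out lower numbers stand for an effect already at smaller amounts and higher numbers for an effect only at larger amounts of compound. Compound 2 `COc1cc(C2Oc3cc([C@H]4Oc5cc(O)cc(O)c5C(=O)[C@@H]4O)ccc3OC2COC(=O)c2cc(OC)c(OC)c(OC)c2)ccc1O` gives 94800 nM in this assay. Compound 3 `COc1cc(C2Oc3cc([C@H]4Oc5cc(O)cc(O)c5C(=O)[C@@H]4O)ccc3OC2COC(=O)c2cccc(Cl)c2)ccc1O` gives 106000 nM in this assay. Compound 3 sits within the scatter of both others: a 1.4-fold higher number from compound 1 to compound 3 (0.16 log units; within the scatter) and a 1.1-fold higher number from compound 2 to compound 3 (0.05 log units; within the scatter), and likewise a 1.3-fold higher number from compound 1 to compound 2 (0.11 log units; within the scatter).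

Compound 4 `CCOC(=O)CC(=O)OCC1Oc2ccc([C@H]3Oc4cc(O)cc(O)c4C(=O)[C@@H]3O)cc2OC1c1ccc(O)c(OC)c1` differs from compound 3 by (ethoxycarbonyl)methyl in place of 3-chlorophenyl on a carbonyl carbon. Within the data shown here, the three measured steps all exchange one aryl group for another on that carbonyl carbon and none moved beyond the scatter; no measured step replaces an aryl group with a chain, so their bearing on this change is only indirect. With nothing pointing either way, no step beyond the scatter is expected, no change at the digits printed from compound 3 to compound 4 (within the scatter). Compound 4 is therefore estimated at 106000 nM in this assay, with a range from 40000 nM to 280000 nM.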

Compound 4, half-maximal effective concentration: 101000 nM
Compound 4: the middle estimate sits 1.0-fold (0.02 log units) above what was measured; the range from low to high includes it.
By their numbers in this assay, from the lowest: compounds 1, 2, 4 and 3 (each within the scatter of the next).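

In this assay the step from aryl to chain at this carbonyl carbon stays small: a 1.0-fold lower number from compound 3 to compound 4 (0.02 log units; within the scatter) and a 1.1-fold higher number from compound 2 to compound 4 (0.03 log units; within the scatter) and a 1.4-fold higher number from compound 1 to compound 4 (0.14 log units; within the scatter) all lie within the scatter. The position therefore accepts (ethoxycarbonyl)methyl, with no ring and two hydrogen-bond acceptors, in place of 3-chlorophenyl, with one aromatic ring and none, without a step beyond the scatter. Nothing available explains why the number stays put. As far as these compounds go, whether an amine, a carboxylic acid or a longer chain on this carbonyl carbon would give a step beyond the scatter remains open. Also open, from the compounds shown here alone, is whether changes elsewhere on the shared core would move the number more than changes at this ester.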